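The source may hold more compounds than are shown below. What is called first, only, known or untested is meant among the compounds shown, and "the series" means these compounds.

Measured so far in a functional assay on the whole organism with Mus musculus as the target, in the maximal electroshock model, with a stated time of 120 min; a higher number here means that more compound is needed for the effect, a lower number that less compound is needed:
Compound 1, `CCCCCCCCCc1cccc(N2CCNCC2)n1`: compound 1 gives 10 mg/kg.
Compound 2, `CCCCCCCc1cccc(N2CCN(C)CC2)n1`: compound 2 gives 30 mg/kg.

Of the two numbers in this assay, compound 1 holds the lower one; its nearest neighbour is compound 2, whose value is a higher one, and the gap between them lies beyond the scatter of the method. No single-point comparison links compound 1 to compound 2, so the two values show only that much.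

Compound 3, `CCCCCc1cccc(N2CCNCC2)n1`, is yet to be measured in this assay. It differs from compound 1 in one place: hydrogen in place of butyl on a saturated chain carbon, five bonds along the chain from an aromatic carbon. With nothing measured along this line of change, the size and direction of the step are uncertain; the account expects a modest move toward a higher number, as a 3.0-fold higher number from compound 1 to compound 3 (0.48 log units; beyond the scatter), though a step within the scatter would not surprise. Compound 3 is estimated at 30 mg/kg, within a range from 10 mg/kg to 100 mg/kg.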

Compound 3, minimum effective dose: 10 mg/kg
Estimate against measurement, compound 3: 3.0-fold (0.48 log units) above; the measured number falls inside the stated range.
By their numbers in this assay, from the lowest: compounds 1 and 3 (each within the scatter of the next); then compound 2.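

The step from butyl to hydrogen on a saturated chain carbon, five bonds along the chain from an aromatic carbon, gives no change at the digits printed from compound 1 to compound 3 (within the scatter) in this assay. Among the compounds shown here, this is the first single-place comparison, and it shows that, for this pair, the butyl at this place can be replaced by hydrogen without a change beyond the scatter. No supporting measurement explains this result.

The compounds shown leave open whether the value would hold if the chain were cut further, with ethyl or methyl in place of pentyl, or if a primary amine or a carboxylic acid stood at the chain end. They also leave open how much a longer chain than that of compound 1 would matter, and compound 2 stays unconnected to compound 1 or compound 3 by any single-place step.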